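This account rests on a few compounds, and the source may have more. Where it says the series, first, only, none or still open, it means among the compounds named here.

Among the compounds with values here, compound 2 `Cc1cc(-c2cc(F)cc(F)c2)cc(C)c1Nc1ccnc(Nc2ccc(C#N)cc2)n1` has the highest of the two numbers measured so far in an ADME assay on MT4 cells (Homo sapiens) for cytotoxicity, read by MTT assay, with a stated time of 4 days (a lower number here means that less compound is tolerated, a higher number that more compound is tolerated), giving 3910 nM. Within the data shown here, its only neighbour, compound 1 `COc1cccc(-c2cc(C)c(Nc3ccnc(Nc4ccc(C#N)cc4)n3)c(C)c2)c1`, gives 2990 nM, and the step of a 1.3-fold higher number from compound 1 to compound 2 (0.12 log units; within the scatter) shows that these two compounds cannot be told apart by this measurement. Compound 3 `Cc1cc(-c2ccccc2)cc(C)c1Nc1ccnc(Nc2ccc(C#N)cc2)n1` differs from compound 2 by phenyl in place of 3,5-difluorophenyl on an aromatic carbon. Among the measured compounds shown here, the one measured step that bears on this change is the one from compound 1 to compound 2, which also replaced one six-membered aromatic ring of carbon only by another on the same aromatic carbon, and it stayed within the scatter. On that basis the step of a 1.1-fold lower number from compound 2 to compound 3 (0.05 log units; within the scatter) is expected to be small, with no direction beyond the scatter. Compound 3 is therefore estimated at 3500 nM, with a range from 1800 nM to 7000 nM.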

Compound 3, half-maximal cytotoxic concentration: 4170 nM
Beside the measured number, compound 3's estimate is 1.2-fold (0.08 log units) below it, within the range that was stated.
By their numbers in this assay, from the lowest: compounds 1, 2 and 3 (each within the scatter of the next).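

In this assay, removing both fluorines from the ring at this position gives a 1.1-fold higher number from compound 2 to compound 3 (0.03 log units; within the scatter), and removing the methoxy gives a 1.4-fold higher number from compound 1 to compound 3 (0.14 log units; within the scatter). Within the data shown here, until now, only two substituted rings could be compared; compound 3 adds a plain phenyl as a reference point, with no group on that ring. Neither the two fluorines nor the methoxy separates its compound from that plain phenyl by more than the scatter, so all three compounds read alike in this measurement.

Nothing available explains why these changes leave the number so flat. From the compounds shown here alone, it remains open whether a different kind of group on this ring, such as an amine or a carboxylic acid, or a longer chain in place of the ring, would shift the number beyond the scatter.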